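A few compounds are considered here, and "the series" means these few. Any claim that something is new, unique, unknown or untested is made for them only; others in the source may bear on it.

Measured compounds:
- Compound 1, `COc1ccc([C@@H]2[C@@H](c3ccccc3)N[C@]3(C(=O)Nc4ccc(Cl)cc43)[C@]23CNc2c(cccc2[N+](=O)[O-])C3=O)cc1`, gives 16000 nM in a functional assay on HeLa cells (Homo sapiens) for cytotoxicity, read by MTT assay, with a stated time of 72 h; a lower number here means a stronger inhibitor, a higher number a weaker inhibitor.
- Compound 2, `O=C1c2cccc([N+](=O)[O-])c2NC[C@@]12[C@H](c1ccc(F)cc1)[C@@H](c1ccccc1)N[C@]21C(=O)Nc2ccc(Br)cc21`, gives 26000 nM in this assay.

Compound 2 holds the highest of the two numbers in this assay, but its nearest neighbour, compound 1, lies within the scatter of it, so the two compounds cannot be told apart on these values. Among the measured compounds shown here, no step between measured compounds that differ in one place is available.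

Compound 3, `COc1ccc([C@@H]2[C@@H](c3ccccc3)N[C@]3(C(=O)Nc4ccc(Br)cc43)[C@]23CNc2c(cccc2[N+](=O)[O-])C3=O)cc1`, is not yet measured. It differs from compound 2 by methoxy in place of fluoro on an aromatic carbon. For the measured compounds named here, the only other compound, compound 1, carries the same methoxy group and gives a number within the scatter of compound 2, so nothing here points to a step beyond the scatter. Compound 3 is expected to give about 18000 nM in this assay, between 8000 nM and 40000 nM. The expected step of a 1.4-fold lower number from compound 2 to compound 3 (0.16 log units; within the scatter) is thus estimated to be no larger than the scatter.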

Compound 3, half-maximal inhibitory concentration: 19000 nM
Compound 3: middle estimate off by 1.1-fold (0.02 log units), on the low side; low and high end bracket the measured number.
By their numbers in this assay, from the lowest: compounds 1, 3 and 2 (each within the scatter of the next).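

Among the compounds shown here, with the methoxy group in place of fluoro on the aromatic carbon para to a large group, this assay gives the first direct reading of this change, and the step is a 1.4-fold lower number from compound 2 to compound 3 (0.14 log units; within the scatter). For the compounds shown here, compound 3 also gives the first direct reading at the halogen place on the shared core, with bromo in place of chloro, and this step is a 1.2-fold higher number from compound 1 to compound 3 (0.07 log units; within the scatter). Both changes therefore stay within the scatter, so neither can be told apart from its counterpart in this assay, and no other measurement bears on these results.

The compounds shown leave open whether an amine, a carboxylic acid or a longer chain in place of the methoxy group would give a step beyond the scatter. They also leave open whether a hydroxyl group or a nitrile at the halogen place would do so.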